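The source may report more compounds than this note shows. Statements on the series, on what has been measured and on what is new or still open speak of the compounds shown alone.

Measured values in an assay on isolated protein (strain Sprague-Dawley) for inhibition of Amine oxidase [flavin-containing] B (Rattus norvegicus), read by spectrophotometry, with a stated time of 5 min; a lower number here means a stronger inhibitor, a higher number a weaker inhibitor:

Compound 1 `CC(C)Oc1cc(=O)oc2cc(OCc3cccc(Cl)c3)ccc12`: 24500 nM
Compound 2 `COCOc1cc(=O)oc2cc(OCc3cccc(Cl)c3)ccc12`: 100 nM
Compound 3 `CN(C)C(=O)COc1cc(=O)oc2cc(OCc3cccc(Cl)c3)ccc12`: 501 nM

Compound 3 stands second highest of the three numbers in this assay. Its nearest neighbour is compound 2, with a 5.0-fold higher number from compound 2 to compound 3 (0.70 log units; beyond the scatter); the furthest is compound 1, with a 49-fold lower number from compound 1 to compound 3 (1.69 log units; beyond the scatter). The other measured step, a 250-fold lower number from compound 1 to compound 2 (2.39 log units; beyond the scatter), is likewise large, so the group on this oxygen of the shared core has so far been the main lever on the number.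

Compound 4 `CCOC(=O)Nc1cc(=O)oc2cc(OCc3cccc(Cl)c3)ccc12` replaces the whole of that group: (ethoxycarbonyl)amino in place of (dimethylcarbamoyl)methoxy on an aromatic carbon. Going by the values given here, no measured step swaps the ring oxygen itself for a nitrogen-linked carbamate, so the three steps bear only indirectly: they show that changes at this position can move the number by large amounts in either direction, while the step from a methoxy to a dimethylcarbamoyl carbon was modest. Without a closer precedent, no confident direction is taken, and the expected step of a 1.2-fold higher number from compound 3 to compound 4 (0.08 log units; within the scatter) is centred near no change, with a wide range to cover the large swings seen at this position.

Compound 4 is therefore expected to give about 600 nM in this assay, within a range from 60 nM to 6000 nM.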

Compound 4, half-maximal inhibitory concentration: 589 nM
For compound 4 the middle estimate is 1.0-fold (0.01 log units) above the measured one; the measured number falls inside the stated range.
By their numbers in this assay, from the lowest: compound 2; then compounds 3 and 4 (each within the scatter of the next); then compound 1.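

In this assay, (ethoxycarbonyl)amino on the aromatic carbon opposite the ring oxygen sits level with (dimethylcarbamoyl)methoxy (a 1.2-fold higher number from compound 3 to compound 4 (0.07 log units; within the scatter)), so a substituent attached through nitrogen and carrying 1 hydrogen-bond donor can take this place without a shift beyond the scatter. An oxygen link at this place is therefore not required for a number in this range, and the large difference from isopropoxy persists with the new link (a 42-fold lower number from compound 1 to compound 4 (1.62 log units; beyond the scatter)). Methoxymethoxy still gives the lower number, by a modest step (a 5.9-fold higher number from compound 2 to compound 4 (0.77 log units; beyond the scatter)), so neither of the two larger substituents in compounds 3 and 4 matches it in this assay. Nothing at hand explains why these different substituents give numbers within the scatter of each other.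

Open, as far as these compounds go, is what the nitrogen link itself contributes, which a direct pairing of methoxymethyl on nitrogen with the methoxymethoxy of compound 2, or a free amine at this place, would address. Also open, from the compounds shown here alone, is how the carbamate end tolerates change, for instance a longer chain such as butoxycarbonyl or a methyl on the carbamate nitrogen in place of the hydrogen.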